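Amide-to-amide swap on a furan carboxamide core

A few compounds are considered here, and "the series" means these few. Any claim that something is new, unique, unknown or untested is made for them only; others in the source may bear on it.

Measured compounds:
compound 1, `Cc1c(C(=O)NCCCN(C)C)oc2ccc(N(Cc3ccc(Br)cc3)S(=O)(=O)c3ccc(Br)cc3)cc12`, 3730 nM
compound 2, `Cc1c(C(=O)OCCCN(C)C)oc2ccc(N(Cc3ccc(Br)cc3)S(=O)(=O)c3ccc(Br)cc3)cc12`, 7050 nM

Of the compounds shown here, two have been measured in a functional assay on HCT-116 cells (Homo sapiens) for antiproliferative activity, read by MTT assay, with a stated time of 48 h; a higher number here means a weaker inhibitor, a lower number a stronger inhibitor. Compound 1 gives 3730 nM. Compound 2 gives 7050 nM. Compound 2 sits at one end of the two numbers shown, but the only gap that separates it from compound 1, a 1.9-fold higher number from compound 1 to compound 2 (0.28 log units; within the scatter), is within the scatter, so the two compounds cannot be told apart on these data.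

The unmeasured compound 3, `Cc1c(C(=O)N2CCCC(C)C2)oc2ccc(N(Cc3ccc(Br)cc3)S(=O)(=O)c3ccc(Br)cc3)cc12`, differs from compound 2 in one place: 3-methylpiperidin-1-yl in place of 3-(dimethylamino)propoxy on a carbonyl carbon. Among the compounds with values here, no measured step covers this change. Within the data shown here, the one step available, a 1.9-fold higher number from compound 1 to compound 2 (0.28 log units; within the scatter), concerns a different exchange on the same carbonyl carbon and was itself within the scatter; it gives no basis for expecting a shift beyond the scatter here, and no direction for one.

Compound 3 is therefore expected to give 5500 nM in this assay, within a range of 1800 nM to 17000 nM. Compound 3 is expected to show a 1.3-fold lower number from compound 2 to compound 3 (0.11 log units; within the scatter) relative to compound 2, which is no step beyond the scatter.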

Compound 3, half-maximal inhibitory concentration: 28300 nM
The estimate for compound 3 lay 5.1-fold (0.71 log units) below the measured number, outside the stated range (above it).
By their numbers in this assay, from the lowest: compounds 1 and 2 (each within the scatter of the next); then compound 3.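

In this assay, the carbonyl carbon proves sensitive to what it carries: 3-methylpiperidin-1-yl in place of 3-(dimethylamino)propoxy gives a 4.0-fold higher number from compound 2 to compound 3 (0.60 log units; beyond the scatter), and the same group in place of (3-(dimethylamino)propyl)amino gives a 7.6-fold higher number from compound 1 to compound 3 (0.88 log units; beyond the scatter). The earlier exchange at this carbon, a 1.9-fold higher number from compound 1 to compound 2 (0.28 log units; within the scatter), had shown no change that could be read, so these are the first steps here to lie beyond the scatter, and compound 3 stands as the weakest of the three compounds, whichever chain it is compared with. No supporting measurement bears on why the number rises with this change.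

The change replaces an open chain carrying a dimethylamino group with a methyl-substituted ring, and these compounds cannot show whether the ring, the methyl group or the loss of the dimethylamino group accounts for the step. Also open, on these data alone, is how this assay would read with an unsubstituted piperidin-1-yl, a 4-methylpiperazin-1-yl or a morpholin-4-yl on this carbonyl carbon, or with a shorter (2-(dimethylamino)ethyl)amino chain.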